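From phenoxy to 2-chlorophenyl in compound 4

The source may report more compounds than this note shows. Statements on the series, on what has been measured and on what is new or still open speak of the compounds shown alone.

compound 1 `CCOC(=O)c1c(-c2cccc(Oc3ccccc3)c2)[nH]c2cc(OC)ccc2c1=O`: > 21500 nM (a limit)
compound 2 `CCOC(=O)c1c(-c2cccc(Oc3ccccc3)c2)[nH]c2cc(OC)c(Cl)cc2c1=O`: > 21500 nM (a limit)
compound 3 `CCOC(=O)c1c(-c2cccc(Oc3ccccc3)c2)[nH]c2cc(OC)c(F)cc2c1=O`: > 21500 nM (a limit)

In an ADME assay on Raji cells (Homo sapiens) for cytotoxicity, read by luminescence, with a stated time of 72 h (a lower number here means that less compound is needed, a higher number that more compound is needed for the effect), compound 3 stands at > 21500 nM as a limit and not a number. Its standing is the limit of > 21500 nM in this assay, at which 3 of the 3 values shown sit, and no measured value lies elsewhere. Compound 4 `CCOC(=O)c1c(-c2cccc(-c3ccccc3Cl)c2)[nH]c2cc(OC)c(F)cc2c1=O` carries 2-chlorophenyl in place of phenoxy on an aromatic carbon, as 2-chlorophenyl in place of phenoxy on an aromatic carbon shows. The measured steps a step that the two limits leave unreadable from compound 1 to compound 2 and a step that the two limits leave unreadable from compound 1 to compound 3 and a step that the two limits leave unreadable from compound 2 to compound 3 give no readable size, and none of them touches phenoxy. The expected step is a number no higher from compound 3 to compound 4 (the limit leaves the size open) with no direction that these data can support. For compound 4 the estimate is 21500 nM in this assay with 9000 nM to 40000 nM as the expected range.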

Compound 4, half-maximal effective concentration: > 21500 nM
Compound 4: no number, only a limit; the forecaster's own chance of this, stated with the estimate: 80%; the middle value lies on the limit itself.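

Compound 4 gives > 21500 nM, a limit and not a number, so no step can be read between compound 3 and compound 4. The compounds shown leave open whether any change among compound 1, compound 2, compound 3 and compound 4 shifts the read-out in this assay at all.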